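Moving the bromine: from compound 2 to compound 3

This account rests on a few compounds, and the source may have more. Where it says the series, first, only, none or still open, it means among the compounds named here.

- compound 1 `CC(C)(C)c1ccc(OCCCON2C(N)=NC(N)=NC23CCSCC3)cc1`: 1 nM
- compound 2 `NC1=NC2(CCSCC2)N(OCCCOc2ccc(Br)cc2)C(N)=N1`: 740 nM

In a functional assay on A549 cells (Homo sapiens) for antiproliferative activity, read by MTT assay, with a stated time of 72 h (on this read-out higher numbers stand for weaker inhibition and lower numbers for stronger inhibition), compound 2 gives 740 nM, the higher of the two numbers, so it is the weaker inhibitor. Compound 3 `NC1=NC2(CCSCC2)N(OCCCOc2cccc(Br)c2)C(N)=N1` has the same atoms, joined differently: 3-bromophenyl in place of 4-bromophenyl on an oxygen on a saturated carbon. Going by the values given here, the only measured step, a 740-fold higher number from compound 1 to compound 2 (2.87 log units; beyond the scatter), was large, but it exchanged tert-butyl for bromo and does not test this kind of change. No step beyond the scatter is therefore expected in this assay, although uncertainty remains wide. The expected step is a 1.5-fold lower number from compound 2 to compound 3 (0.17 log units; within the scatter). For compound 3 the estimated value is 500 nM, with an expected range of 100 nM to 2500 nM.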

Compound 3, half-maximal inhibitory concentration: 50 nM
The estimate for compound 3 lay 10-fold (1.00 log units) above the measured number; the whole stated range lies above it.
By their numbers in this assay, from the lowest: compound 1; then compound 3; then compound 2.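

In this assay moving the bromine alone gives a 15-fold lower number from compound 2 to compound 3 (1.17 log units; beyond the scatter) and so shows that 3-bromophenyl and 4-bromophenyl are not interchangeable here, even with the same atoms. The earlier step exchanged one group for another, tert-butyl for bromo, and could not separate where a group sits from what it is. Nothing available explains the difference between these two placements. Going by these compounds, whether moving the tert-butyl group of compound 1 in the same way would have a similar effect remains open, as does what a chlorine or a methoxy group would do in place of the bromine.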